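A hydroxy group added where only limits are known

A few compounds are considered here, and "the series" means these few. Any claim that something is new, unique, unknown or untested is made for them only; others in the source may bear on it.

In a functional assay on L1210 cells (Mus musculus) for antiproliferative activity, read by MTT assay (on this read-out lower numbers stand for stronger inhibition and higher numbers for weaker inhibition), compound 1, `O=C(N/N=C/c1ccccc1)c1cn(C2CC2)c2cc(N3CCNCC3)c(F)cc2c1=O`, gives <= 25000 nM, which is a limit of the assay and not a number. Compound 2, `COc1ccc(/C=N/NC(=O)c2cn(C3CC3)c3cc(N4CCNCC4)c(F)cc3c2=O)cc1`, carries a methoxy in place of hydrogen on an aromatic carbon, and in this assay compound 2 gives <= 25000 nM, again a limit. Compound 2 therefore has no exact number of its own, and the evidence so far is the limit of <= 25000 nM in this assay, at which 2 of the 2 values shown sit.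

Compound 3, `COc1ccc(/C=N/NC(=O)c2cn(C3CC3)c3cc(N4CCNCC4)c(F)cc3c2=O)cc1O`, differs from compound 2 in one place: hydroxy in place of hydrogen on an aromatic carbon. The new group is a hydroxy in place of hydrogen on an aromatic carbon, and the ring becomes 3-hydroxy-4-methoxyphenyl. Among the compounds with values here, the only measured step is a step that the two limits leave unreadable from compound 1 to compound 2, and it offers no size to carry over to this change, so no clear step in either direction is expected in this assay. The estimated step is a step that the limit leaves unreadable from compound 2 to compound 3. For compound 3 the estimate is 15000 nM, with an expected range from 5000 nM to 30000 nM, and the assay may well report just a limit again.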

Compound 3, half-maximal inhibitory concentration: <= 25000 nM
Compound 3: only a limit was reported; the forecaster's own chance of this, stated with the estimate: 55%; the middle value lies beyond the limit too.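

Compound 3 gives only a limit and not a number, as do compound 1 and compound 2, so no step among these compounds can be read in this assay: the limit of <= 25000 nM in this assay, at which 3 of the 3 values shown sit.

The compounds shown leave open how strong each of the three really is, and whether the methoxy or the hydroxy changes the read-out at all.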